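From propyl to trifluoromethoxy: what the numbers suggest

The source may report more compounds than this note shows. Statements on the series, on what has been measured and on what is new or still open speak of the compounds shown alone.

Compound 1 `CCCc1ccc(-c2cc(=O)c3c(o2)C(CC)(CC)C(=O)C(CC)=C3O)cc1` was examined in a functional assay on KB cells (Homo sapiens) for antiproliferative activity, read by sulforhodamine B assay, with a stated time of 3 days; a lower number here means that less compound is needed, a higher number that more compound is needed for the effect. For compound 1 the reading > 53 uM is a limit of the assay rather than a number, which is the limit of > 53 uM in this assay, at which 1 of the 2 values shown sits. Compound 2 `CCC1=C(O)c2c(oc(-c3ccc(C(F)(F)F)cc3)cc2=O)C(CC)(CC)C1=O` gives 35.7 uM in this assay. Going by the values given here, the only measured step that bears here is an at least 1.4-fold lower number from compound 1 to compound 2 (0.17 log units; that floor lies within the scatter), which swaps the propyl for trifluoromethyl. Compound 3 `CCC1=C(O)c2c(oc(-c3ccc(OC(F)(F)F)cc3)cc2=O)C(CC)(CC)C1=O` differs from compound 1 by trifluoromethoxy in place of propyl on an aromatic carbon. A step of similar, modest size, if any beyond the scatter, is therefore expected, namely an at least 1.3-fold lower number from compound 1 to compound 3 (0.12 log units; that floor lies within the scatter). Compound 3 is accordingly estimated at 40 uM, with a range from 15 uM to 110 uM.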

Compound 3, concentration for half-maximal effect: 36.5 uM
Beside the measured number, compound 3's estimate is 1.1-fold (0.04 log units) above it, within the range that was stated.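

Replacing trifluoromethyl with trifluoromethoxy gives a 1.0-fold higher number from compound 2 to compound 3 (0.01 log units; within the scatter), so in this assay these two groups cannot be told apart at this position, on an aromatic carbon para to a large group. Replacing propyl with trifluoromethoxy gives an at least 1.4-fold lower number from compound 1 to compound 3 (0.16 log units; that floor lies within the scatter), so this second replacement of propyl also shows no change beyond the scatter. The reading for compound 1 is a limit, not a number: the limit of > 53 uM in this assay, at which 1 of the 3 values shown sits.

Going by these compounds, whether an amine, a carboxylic acid or a longer chain at this position would shift the number beyond the scatter remains open. On these data alone, the true value of compound 1 also remains open.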